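Moving the Chlorine on the Amide Ring of Compound 2

The compounds below may be only part of what the source reports. "The series", "measured", "known", "first", "only" and "open" are said of these compounds alone.

For the measured compounds named here, compound 2 `C[C@@H](NC(=O)c1cccc(Cl)c1)[C@H]1CC[C@@H](c2ccnc3ccc(F)cc32)CC1` is the stronger of the two compounds measured so far in an assay on tissue (HeLa cells) for inhibition of Indoleamine 2,3-dioxygenase 1 (Homo sapiens), with stated times of 2 h and 18 h; on this read-out higher numbers stand for weaker inhibition and lower numbers for stronger inhibition: compound 2 gives 7 nM, while compound 1 `C[C@@H](NCc1ccc(Cl)cc1)[C@H]1CC[C@@H](c2ccnc3ccc(F)cc32)CC1` gives 745 nM. Going by the values given here, the single measured step, a 110-fold lower number from compound 1 to compound 2 (2.03 log units; beyond the scatter), changed two things at once: a 4-chlorobenzyl on the amine nitrogen became a (3-chlorophenyl)carbonyl, so both the link to the ring and the place of the chlorine on that ring moved together.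

Compound 3 `C[C@@H](NC(=O)c1ccccc1Cl)[C@H]1CC[C@@H](c2ccnc3ccc(F)cc32)CC1` keeps the carbonyl link and changes only the ring: 2-chlorophenyl in place of 3-chlorophenyl on a carbonyl carbon. Among the compounds with values here, no measured step separates the place of the chlorine from the change of link, so the one large step gives no direct guide to this smaller change. With that gap in the data, the expectation for compound 3 in this assay is a modest weakening that may well stay within the scatter, a 2.1-fold higher number from compound 2 to compound 3 (0.33 log units; beyond the scatter), and the estimate for compound 3 is 15 nM, with a range from 4 nM to 60 nM.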

Compound 3, half-maximal inhibitory concentration: 12 nM
Compound 3: middle estimate off by 1.3-fold (0.10 log units), on the high side; measured number inside the range.
By their numbers in this assay, from the lowest: compounds 2 and 3 (each within the scatter of the next); then compound 1.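

In this assay, moving the chlorine on the ring attached to the carbonyl carbon gives a 1.7-fold higher number from compound 2 to compound 3 (0.23 log units; within the scatter), so compound 2 and compound 3 cannot be told apart on this read-out, and the 3-chlorophenyl and 2-chlorophenyl groups serve equally well here. The other new comparison, a 62-fold lower number from compound 1 to compound 3 (1.79 log units; beyond the scatter), is large, like the earlier step from compound 1, so both carbonyl compounds now stand well clear of compound 1, although each of these steps still changes the link and the place of the chlorine together. The data shown offer no measurement that explains why these two chlorine places read alike.

Still open, on these data alone, is how much of the large gap belongs to the link itself, a question that a 2-chlorobenzyl or 3-chlorobenzyl group on the amine nitrogen could help to settle by comparison with compound 3 or compound 2. Also open, as far as these compounds go, is whether the ring needs a chlorine at all, which a plain phenyl, or a fluorine or nitrile in place of the chlorine, could test.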